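The source may report more compounds than this note shows. Statements on the series, on what has been measured and on what is new or still open speak of the compounds shown alone.

Of the compounds shown here, two have been tested so far, compound 1 (`O=C(N/N=C/c1c[nH]c2ccc(Br)cc12)C(=O)c1c[nH]c2ccccc12`) and compound 2 (`O=C(N/N=C/c1c[nH]c2ccccc12)C(=O)c1cn(Cc2ccc(Cl)cc2)c2ccccc12`). In a functional assay on Jurkat cells (Homo sapiens) for cytotoxicity, read by MTT assay, with a stated time of 48 h (on this read-out lower numbers stand for stronger inhibition and higher numbers for weaker inhibition), compound 1 gives 5000 nM and compound 2 gives 220 nM, the lower of the two numbers by a gap beyond the scatter. Compound 3 (`COc1ccc2[nH]cc(/C=N/NC(=O)C(=O)c3cn(Cc4ccc(Cl)cc4)c4ccccc34)c2c1`) is compound 2 with methoxy in place of hydrogen on an aromatic carbon. Within the data shown here, no measured pair shows this change on its own, so no shift beyond the scatter is expected in either direction, and the estimated change is a 1.1-fold lower number from compound 2 to compound 3 (0.04 log units; within the scatter). Compound 3 is therefore expected at 200 nM, with an estimated range of 60 nM to 700 nM.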

Compound 3, half-maximal inhibitory concentration: 3600 nM
Beside the measured number, compound 3's estimate is 18-fold (1.26 log units) below it; the measured number lies above the stated range.
By their numbers in this assay, from the lowest: compound 2; then compounds 3 and 1 (each within the scatter of the next).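

In this assay, going from 1H-indol-3-yl to 5-methoxy-1H-indol-3-yl gives a 16-fold higher number from compound 2 to compound 3 (1.21 log units; beyond the scatter), a large step. This carbon of the ring is therefore not indifferent to what it carries: replacing one hydrogen with methoxy is enough to lose most of the strength of compound 2. Nothing available here explains why the number rises so far. As far as these compounds go, whether a hydroxyl, an amine or a chlorine on this same carbon would cost as much remains open. So does whether methoxy has the same effect in other parts of the molecule.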